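Shifting the methoxy group on compound 1 and its expected effect

This account rests on a few compounds, and the source may have more. Where it says the series, first, only, none or still open, it means among the compounds named here.

Compound 1 `COc1ccccc1-n1cc(COC(=O)/C(C)=C/CC/C(C)=C/CC/C(C)=C/CC[C@@H]2[C@@]3(C)CCC(=O)C(C)(C)[C@H]3CC[C@@]2(C)O)nn1` was examined in a functional assay on A549 cells (Homo sapiens) for antiproliferative activity, read by MTT assay, with a stated time of 48 h; a lower number here means a stronger inhibitor, a higher number a weaker inhibitor. In this assay compound 1 gives > 150000 nM, which is a limit of the assay and not a number. Compound 2 `C/C(=C\CC/C(C)=C/CC[C@@H]1[C@@]2(C)CCC(=O)C(C)(C)[C@H]2CC[C@@]1(C)O)CC/C=C(\C)C(=O)OCc1cn(-c2ccc(Br)cc2)nn1` carries 4-bromophenyl in place of 2-methoxyphenyl on an aromatic nitrogen. In this assay compound 2 gives > 150000 nM, again only a limit. The step that the two limits leave unreadable from compound 1 to compound 2 stays unreadable in size because of the limit of > 150000 nM in this assay, at which 2 of the 2 values shown sit. Compound 3 `COc1cccc(-n2cc(COC(=O)/C(C)=C/CC/C(C)=C/CC/C(C)=C/CC[C@@H]3[C@@]4(C)CCC(=O)C(C)(C)[C@H]4CC[C@@]3(C)O)nn2)c1` differs from compound 1 in that (3-methoxyphenyl in place of 2-methoxyphenyl on an aromatic nitrogen); the two have the same atoms, joined differently. Among the compounds with values here, only the unreadable step from compound 1 to compound 2 bears on this change, so no measured step gives a size or direction to expect in this assay beyond the scatter. Since compound 1 stands at the limit, compound 3 is expected to give 200000 nM, within 80000 nM to 600000 nM. The expected step that the limit leaves unreadable from compound 1 to compound 3 is estimated to be no larger than the scatter.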

Compound 3, half-maximal inhibitory concentration: > 150000 nM
Compound 3 was reported as a limit (the forecaster's own chance of this, stated with the estimate: 85%); the middle value lies beyond the limit too.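

The steps from compound 1 to compound 3 and from compound 2 to compound 3 cannot be read in this assay because all three compounds sit at the same limit: the limit of > 150000 nM in this assay, at which 3 of the 3 values shown sit.

The compounds shown leave open whether 2-methoxyphenyl, 3-methoxyphenyl and 4-bromophenyl differ at all in this assay, and whether any group on this aromatic nitrogen gives a measurable value.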